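Compound 4 Awaits Its Reading After One Change at a Ring Nitrogen

The compounds below may be only part of what the source reports. "The series", "measured", "known", "first", "only" and "open" are said of these compounds alone.

Compound 1, `Cn1c(-c2ccc(NC(=O)CCl)cc2)nc(-c2ccccc2)c1-c1ccccc1`, gives 4.3% in a functional assay on MCF7 cells (Homo sapiens) for cytotoxicity, read by MTT assay, with a stated time of 24 h, tested at 1.6 ug/mL; a lower number here means a weaker effect, a higher number a stronger effect of the compound at the concentration tested.
Compound 2, `Cc1ccc2oc(SCC(=O)Nc3ccc(-c4nc(-c5ccccc5)c(-c5ccccc5)n4C)cc3)nc2c1`, gives 1.9% in this assay.
Compound 3, `CN(C)/C=C/N1CCN(CC(=O)Nc2ccc(-c3nc(-c4ccccc4)c(-c4ccccc4)n3C)cc2)CC1`, gives 1.9% in this assay.

All three share one core and differ only in the group on the saturated chain carbon bound to the carbonyl carbon. Compound 3 stands level with compound 2 at the digits shown, the two together the lowest of the three numbers; its nearest neighbour is compound 2, with no change at the digits shown, and its furthest is compound 1, a slightly higher number that still lies within the scatter. None of the three shows much effect at the concentration tested.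

Compound 4, `Cn1c(-c2ccc(NC(=O)CN3CCN(Cc4ccc(Cl)cc4)CC3)cc2)nc(-c2ccccc2)c1-c1ccccc1`, has not been measured. It differs from compound 3 by 4-chlorobenzyl in place of 2-(dimethylamino)ethenyl on an amine nitrogen in a ring.

Going by the values given here, no measured step touches this amine nitrogen in the ring. The steps that exist all change the group on the saturated chain carbon bound to the carbonyl carbon: a number 2.4 percentage points lower from compound 1 to compound 2 (within the scatter), a number 2.4 percentage points lower from compound 1 to compound 3 (within the scatter), and no change at the digits printed from compound 2 to compound 3 (within the scatter). Three quite different groups there all leave the read-out near the bottom of the scale, so the step of a number 1.1 percentage points higher from compound 3 to compound 4 (within the scatter) is expected to stay within the scatter. Compound 4 is therefore expected to give 3%, in the range 0% to 12%.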

Compound 4, a percentage reported as activity, at one concentration (the size of the read-out at that concentration, not a potency): 11.8%
Compound 4: middle estimate off by 8.8 percentage points, on the low side; the range from low to high includes it.
By their numbers in this assay, from the lowest: compounds 2, 3, 1 and 4 (each within the scatter of the next).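

Going by these compounds alone, this is the first measured step at the amine nitrogen in the ring, and it is a large change of group: 4-chlorobenzyl, with its six-membered aromatic ring of carbon and its chlorine, in place of 2-(dimethylamino)ethenyl, which has no ring. In this assay this exchange gives a number 9.9 percentage points higher from compound 3 to compound 4 (within the scatter) and so does not separate the two compounds, which means that this position, like the saturated chain carbon bound to the carbonyl carbon, has yet to show a change beyond the usual spread of repeated measurements. A single step cannot show that every group at this nitrogen would behave alike, and nothing shown here offers an explanation for the size of the step.

The compounds shown leave open whether the chlorine has any part in this result, which a plain benzyl group on the same nitrogen could test. They also leave open whether a group of a different kind there, such as a carboxylic acid on a short chain or a bare hydrogen on the nitrogen, would move the read-out clearly beyond the scatter.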